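The compounds below may be only part of what the source reports. "The series", "measured", "known", "first", "only" and "open" are said of these compounds alone.

Two compounds share one core and differ only in the group on an amine nitrogen in a ring. Compound 1 `CCCn1c(=O)[nH]c2nc(-c3ccc(S(=O)(=O)N4CCN(c5ccccc5C)CC4)cc3)[nH]c2c1=O` carries a 2-methylphenyl there, and in an assay on CHO cells for displacement of a labelled ligand from adenosine receptor A2b (Homo sapiens), read by scintillation counting, with a stated time of 75 min, in the presence of a further agent that is not named here (a higher number here means a weaker inhibitor, a lower number a stronger inhibitor), compound 1 gives 0.432 nM. Compound 2 `CCCn1c(=O)[nH]c2nc(-c3ccc(S(=O)(=O)N4CCN(Cc5cccc(Br)c5)CC4)cc3)[nH]c2c1=O` carries a 3-bromobenzyl instead, and in this assay compound 2 gives 0.148 nM. That single change produced a 2.9-fold lower number from compound 1 to compound 2 (0.47 log units; beyond the scatter), so compound 2 holds the lower of the two numbers, with compound 1 as its only comparator. Compound 3 `CCCn1c(=O)[nH]c2nc(-c3ccc(S(=O)(=O)N4CCN(c5cccc(F)c5)CC4)cc3)[nH]c2c1=O` has not yet been measured. It differs from compound 2 by 3-fluorophenyl in place of 3-bromobenzyl on an amine nitrogen in a ring. Within the data shown here, no measured pair shows exactly this change; the only step that bears on it is a 2.9-fold lower number from compound 1 to compound 2 (0.47 log units; beyond the scatter), which replaced a phenyl-type group with a benzyl-type group and lowered the number. Compound 3 returns to a phenyl-type group, as compound 1 has, though a different one. The expectation for compound 3 in this assay is therefore a 2.4-fold higher number from compound 2 to compound 3 (0.37 log units; beyond the scatter), a modest rise rather than a further fall. The estimate for compound 3 in this assay is 0.35 nM, with a range from 0.15 nM to 0.9 nM.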

Compound 3, inhibition constant: 0.632 nM
Estimate against measurement, compound 3: 1.8-fold (0.26 log units) below; the range from low to high includes it.
By their numbers in this assay, from the lowest: compound 2; then compounds 1 and 3 (each within the scatter of the next).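

In this assay, replacing 3-bromobenzyl with 3-fluorophenyl on the amine nitrogen gives a 4.3-fold higher number from compound 2 to compound 3 (0.63 log units; beyond the scatter) and so undoes the gain seen earlier: compound 2 now sits beyond the scatter from both phenyl-type compounds, not just from compound 1. The two phenyl-type groups cannot be told apart here, since 3-fluorophenyl in place of 2-methylphenyl gives a 1.5-fold higher number from compound 1 to compound 3 (0.17 log units; within the scatter) and a methyl group on one ring and a fluorine on the other leave the number within the usual noise. No measurement at hand explains why compound 2 has the lowest number.

Compound 2 is the only benzyl-type compound shown, and the change to compound 3 alters two things at once: the halogen switches from bromine to fluorine, and the carbon linking the aromatic ring to the nitrogen disappears, so the two contributions cannot be separated. A plain benzyl group, a phenyl ring bearing bromine, or a longer chain such as phenethyl would be needed to tell whether the link, the bromine or both account for the difference.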